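A few compounds are considered here, and "the series" means these few. Any claim that something is new, unique, unknown or untested is made for them only; others in the source may bear on it.

Compound 1, `CN(C)c1ccc(C2CC(c3ccc(-n4cncn4)cc3)=NN2C(=O)CCCl)cc1`: in a functional assay on MDA-MB-231 cells (Homo sapiens) for inhibition, read by sulforhodamine B assay, tested at 10 uM (a higher number here means more inhibition at the concentration tested (going by the name of the read-out), a lower number less inhibition), compound 1 gives 3.7%.
Compound 2, `CN(C)c1ccc(C2CC(c3ccc(-n4cncn4)cc3)=NN2C(=O)c2ccc(C(F)(F)F)cc2)cc1`: in this assay compound 2 gives 16.7%.
Compound 3, `CN(C)c1ccc(C2CC(c3ccc(-n4cncn4)cc3)=NN2S(=O)(=O)c2ccc(Br)cc2)cc1`: in this assay compound 3 gives 10.4%.

All three share the same core and differ only in the group on the ring nitrogen. For the measured compounds named here, the one step that clears the scatter is a number 13 percentage points higher from compound 1 to compound 2 (beyond the scatter). Compound 3 stands second highest of the three numbers, but its neighbours lie close: a number 6.3 percentage points lower from compound 2 to compound 3 (within the scatter) and a number 6.7 percentage points higher from compound 1 to compound 3 (within the scatter), so no order among compound 3 and the other two can be read from these values.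

Compound 4, `CN(C)c1ccc(C2CC(c3ccc(-n4cncn4)cc3)=NN2S(=O)(=O)c2ccc(C#N)cc2)cc1`, is the next compound. It differs from compound 3 by cyano in place of bromo on an aromatic carbon. Going by the values given here, none of the measured steps touches this position; the two steps that change the group on the ring nitrogen swap the whole substituent, and the single step beyond the scatter concerns a carbonyl-bearing group. The data therefore give no basis for a directed change, and compound 4 is expected to stay near compound 3, with a number 1.6 percentage points higher from compound 3 to compound 4 (within the scatter) as the estimated step. For compound 4 in this assay the estimate is 12%, within 2% to 26%.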

Compound 4, a percentage reported as inhibition, at one concentration (the size of the read-out at that concentration, not a potency): 32.8%
Compound 4: middle estimate off by 20.8 percentage points, on the low side; the whole stated range lies below it.
By their numbers in this assay, from the lowest: compounds 1, 3 and 2 (each within the scatter of the next, the first and the last beyond it); then compound 4.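

Cyano in place of bromo, on an aromatic carbon para to a large group, gives a number 22.4 percentage points higher from compound 3 to compound 4 (beyond the scatter) in this assay and shows that this outer position matters even when the rest of the (4-bromophenyl)sulfonyl group stays the same. The sulfonyl link alone does not account for the result: compound 3 lies within the scatter of compound 1 and compound 2, whereas the cyano compound shows a number 16.1 percentage points higher from compound 2 to compound 4 (beyond the scatter) and a number 29.1 percentage points higher from compound 1 to compound 4 (beyond the scatter) in the same read-out. No measurement shown here explains why this exchange raises the number.

As far as these compounds go, it remains open how other groups at this position would read, such as an amine, a carboxylic acid or a methoxy group. From the compounds shown here alone, it is equally open whether a 4-cyanophenyl group on a carbonyl rather than a sulfonyl would give a similar number.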